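The source may hold more compounds than are shown below. What is called first, only, known or untested is meant among the compounds shown, and "the series" means these compounds.

Working notes on a set of sulfonamides measured in an assay on isolated protein for inhibition of malate dehydrogenase, mitochondrial (Sus scrofa), with stated times of 45 min and 30 min; a higher number here means a weaker inhibitor, a lower number a stronger inhibitor. Compound 1 `O=S(=O)(Nc1ccc2oc(-c3ccccc3)nc2c1)c1cccc(O)c1` gives only a limit, > 63000 nM, not a number. Compound 3 `O=S(=O)(Nc1ccc2oc(-c3ccccc3)nc2c1)c1ccc(Cl)c(Cl)c1` likewise gives only a limit, > 63000 nM. Going by the values given here, the one measured step between them, a step that the two limits leave unreadable from compound 1 to compound 3, is therefore unreadable. Compound 2 `O=S(=O)(Nc1ccc(-c2nc3ccccc3o2)cc1)c1ccc(O)cc1` also returns only a limit in this assay, > 63000 nM. The whole set rests on (the limit of > 63000 nM in this assay, at which 3 of the 3 values shown sit), so compound 2 stands at the edge of what this assay can read, with no number to rank it against. Compound 4 `O=S(=O)(Nc1ccc(-c2nc3ccccc3o2)cc1)c1ccc(Cl)cc1` differs from compound 2 by chloro in place of hydroxy on an aromatic carbon. No readable step bears on this change, so nothing beyond the scatter is expected, the estimated step being a step that the limit leaves unreadable from compound 2 to compound 4. Compound 4 is thus estimated at 100000 nM, within 30000 nM to 300000 nM.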

Compound 4, half-maximal inhibitory concentration: > 63000 nM
Compound 4 ended at the assay's limit; the forecaster's own chance of this, stated with the estimate: 85%; the middle value is on the limit's open side.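

Compound 2 and compound 4 each give only a limit, so no new step can be read between them, and the whole set rests on a single reading: the limit of > 63000 nM in this assay, at which 4 of the 4 values shown sit. The compounds shown leave open whether chloro in place of hydroxy changes inhibition at all, and how any of them ranks in this assay.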